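Larger alkyl groups on the phenyl ring weaken inhibition

The source may report more compounds than this note shows. Statements on the series, on what has been measured and on what is new or still open speak of the compounds shown alone.

Compound 2 `Cc1cccc(-n2cc(COc3cccc(NC(=O)Nc4ccc(Cl)c(C(F)(F)F)c4)c3)nn2)c1` carries a 3-methylphenyl group on the shared core. In a functional assay on HepG2 cells (Homo sapiens) for inhibition, read by MTT assay, with a stated time of 72 h (on this read-out higher numbers stand for weaker inhibition and lower numbers for stronger inhibition), compound 2 gives 7270 nM, the second highest of the three numbers, sitting between compound 1 `O=C(Nc1cccc(OCc2cn(-c3ccccc3)nn2)c1)Nc1ccc(Cl)c(C(F)(F)F)c1` with 1780 nM and compound 3 `CCc1cccc(-n2cc(COc3cccc(NC(=O)Nc4ccc(Cl)c(C(F)(F)F)c4)c3)nn2)c1` with 37900 nM. Compound 4 `CC(C)c1ccc(-n2cc(COc3cccc(NC(=O)Nc4ccc(Cl)c(C(F)(F)F)c4)c3)nn2)cc1` differs from compound 2 by 4-isopropylphenyl in place of 3-methylphenyl on an aromatic nitrogen. Going by the values given here, the steps that bear on this change are a 4.1-fold higher number from compound 1 to compound 2 (0.61 log units; beyond the scatter), a 21-fold higher number from compound 1 to compound 3 (1.33 log units; beyond the scatter) and a 5.2-fold higher number from compound 2 to compound 3 (0.72 log units; beyond the scatter): the numbers rose as the group on that phenyl ring grew. The entering group, with 9 carbon atoms against 7, is larger still, so a modest to large rise is expected, a 4.8-fold higher number from compound 2 to compound 4 (0.68 log units; beyond the scatter). Compound 4 is therefore estimated at 35000 nM, with a range from 10000 nM to 120000 nM.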

Compound 4, half-maximal inhibitory concentration: 2470 nM
The estimate for compound 4 lay 14-fold (1.15 log units) above the measured number; the whole stated range lies above it.
By their numbers in this assay, from the lowest: compounds 1 and 4 (each within the scatter of the next); then compound 2; then compound 3.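

In this assay the 4-isopropylphenyl group breaks the rise seen with the earlier alkyl groups, with a 2.9-fold lower number from compound 2 to compound 4 (0.47 log units; beyond the scatter) and a 15-fold lower number from compound 3 to compound 4 (1.19 log units; beyond the scatter), while a 1.4-fold higher number from compound 1 to compound 4 (0.14 log units; within the scatter). Compound 4 thus goes against the earlier order, so the number of carbon atoms alone does not set the result at this phenyl ring. Nothing measured here accounts for this.

Going by these compounds, whether the isopropyl group itself or its printed ring place matters stays open, as 4-isopropylphenyl differs from 3-methylphenyl in both. On these data alone, how an amine or a carboxylic acid on this ring would read also remains open.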